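The source may hold more compounds than are shown below. What is called first, only, known or untested is meant among the compounds shown, and "the series" means these compounds.

In a functional assay on HL-60 cells (Homo sapiens) for cytotoxicity, read by WST assay, with a stated time of 48 h (a higher number here means that more compound is needed for the effect, a lower number that less compound is needed), compound 3 `COc1ccc(C[C@H]2C(=O)OC[C@@H]2Cc2ccccc2)cc1` gives 67000 nM. Compound 1 `Cc1ccccc1C[C@H]1C(=O)OC[C@@H]1Cc1ccccc1` gives 57000 nM, and these two values lie within the scatter of each other. Compound 2 `O=C1OC[C@H](Cc2ccccc2)[C@H]1Cc1cccc(O)c1` gives > 100000 nM, which is a limit of the assay and not a number.

Compound 4 `Cc1ccc(C[C@H]2C(=O)OC[C@@H]2Cc2ccccc2)cc1` has not yet been measured. It departs from compound 3 in one place, (methyl in place of methoxy on an aromatic carbon), with methyl in place of methoxy on an aromatic carbon, para to a large group. Going by the values given here, no measured step covers this exchange directly. Among the compounds with values here, the only step available is an at least 1.7-fold higher number from compound 1 to compound 2 (0.24 log units; that floor lies within the scatter), which puts 3-hydroxyphenyl in place of 2-methylphenyl, so it is a different exchange and gives only indirect guidance. From the compounds shown here alone, its size is also open, since it ends at a limit. The closest guide is therefore the pair of values already in hand, with compound 1 at 57000 nM and compound 3 at 67000 nM. On that basis, no step beyond the scatter is expected in this assay, and no direction is favoured with any confidence. The estimated step is a 1.1-fold lower number from compound 3 to compound 4 (0.05 log units; within the scatter). For compound 4 the expected value is 60000 nM, with an estimated range from 30000 nM to 100000 nM.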

Compound 4, half-maximal effective concentration: 44000 nM
Estimate against measurement, compound 4: 1.4-fold (0.13 log units) above, within the range that was stated.
By their numbers in this assay, from the lowest: compounds 4, 1 and 3 (each within the scatter of the next). At a limit, above all of these: compound 2.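

In this assay, methyl in place of methoxy on an aromatic carbon, para to a large group, gives a 1.5-fold lower number from compound 3 to compound 4 (0.18 log units; within the scatter) and so moves the value no further than the scatter at this position. The same holds for the placement of the methyl group, since 4-methylphenyl in place of 2-methylphenyl gives a 1.3-fold lower number from compound 1 to compound 4 (0.11 log units; within the scatter) and leaves compounds 1, 3 and 4 without any order among them. Going by these compounds alone, the one step beyond the scatter, an at least 2.2-fold lower number from compound 2 to compound 4 (0.35 log units; beyond the scatter) for 4-methylphenyl in place of 3-hydroxyphenyl, starts from compound 2, whose value is a limit and not a number, so it gives only a floor for the size of that step: the limit of > 100000 nM in this assay, at which 1 of the 4 values shown sits.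

What an amine, a carboxylic acid or a longer chain would do on the same aromatic carbon stays open, as the methoxy and methyl groups shown there stay within the scatter of each other. The compounds shown also leave open whether any group at this place could bring a step beyond the scatter toward a lower number.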